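Series of aminodicyanophenyl methylsulfanyl compounds: phenyl to benzyl

The source may hold more compounds than are shown below. What is called first, only, known or untested is meant among the compounds shown, and "the series" means these compounds.

Measured so far:
- compound 1 `CSc1c(C#N)c(N)c(C#N)c(-c2ccccc2)c1-c1ccccc1`: "not active" (no number reported)
- compound 2 `COc1ccc(-c2c(C#N)c(N)c(C#N)c(SC)c2-c2ccc(F)cc2)cc1`: "not active" (no number reported)
- compound 3 `CSc1c(C#N)c(N)c(C#N)c(C)c1-c1ccc(F)cc1`: 5%

In an assay on isolated protein for inhibition of glucose-6-phosphatase catalytic subunit 1 (Homo sapiens), tested at 100 uM (a higher number here means more inhibition at the concentration tested (going by the name of the read-out), a lower number less inhibition), compound 1 gives "not active" (no number reported), reported without a number. Compound 2 likewise gives "not active" (no number reported) in this assay, again with no number. Only compound 3 carries a figure: in this assay compound 3 gives 5%, a read-out that does not rise out of the usual scatter of such measurements. Compound 1 therefore stands among the entries for which no single number is known, and nothing in the set so far shows inhibition worth the name.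

Compound 4 `CSc1c(C#N)c(N)c(C#N)c(Cc2ccccc2)c1-c1ccccc1` is not yet measured. It differs from compound 1 by benzyl in place of phenyl on an aromatic carbon. Among the measured compounds shown here, no step between measured compounds is available to calibrate this change. Given that compound 1 shows "not active" (no number reported) and compound 3 shows 5%, the expectation for the step from compound 1 to compound 4 is none beyond the scatter, in either direction. Compound 4 is therefore estimated at 5% in this assay, with a plausible range of 0% to 15%, and a real chance that it is again reported only as not active.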

Compound 4, a percentage reported as inhibition, at one concentration (the size of the read-out at that concentration, not a potency): 11.6%
Compound 4: middle estimate off by 6.6 percentage points, on the low side; the measured number falls inside the stated range.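

In this assay, among the compounds shown here, compound 4 gives 11.6% and compound 1 carries no number, so no step from phenyl to benzyl can be read. Still open, on these data alone, is whether any change on the shared core lifts inhibition clearly beyond the scatter. Nothing at hand explains this read-out.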